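A Nitrophenyl Swap on a Weak Cell-Growth Inhibitor

The compounds below may be only part of what the source reports. "The series", "measured", "known", "first", "only" and "open" are said of these compounds alone.

Measured compounds:
- compound 1 `CC(c1ccc(-c2ccccc2)c(F)c1)c1nnc2n1N=C(c1ccc(Cl)cc1Cl)CS2`: in a functional assay on HCT-116 cells (Homo sapiens) for inhibition, read by sulforhodamine B assay, with a stated time of 72 h (a lower number here means a stronger inhibitor, a higher number a weaker inhibitor), compound 1 gives 6900 nM
- compound 2 `CC(c1ccc(-c2ccccc2)c(F)c1)c1n[nH]c(=S)n1N`: in this assay compound 2 is reported as "not active" (no number reported)

Within the data shown here, compound 1 holds the only number reported in this assay; compound 2 stands beside it without one, so there is nothing to rank compound 1 against. Compound 3 `CC(c1ccc(-c2ccccc2)c(F)c1)c1nnc2n1N=C(c1ccc([N+](=O)[O-])cc1)CS2` keeps the shared core of compound 1 and alters a single group: 4-nitrophenyl in place of 2,4-dichlorophenyl on a carbon with a double bond to nitrogen. Among the measured compounds shown here, no pair of measured compounds shows what such an exchange does in this assay, so the size of the step cannot be read from the data. For the measured compounds named here, the expected step of a 1.2-fold higher number from compound 1 to compound 3 (0.06 log units; within the scatter) is small, in no direction beyond the usual scatter, because the only anchor is compound 1 at 6900 nM. Compound 3 is therefore estimated at 8000 nM, with a range from 2500 nM to 25000 nM that reflects this uncertainty.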

Compound 3, half-maximal inhibitory concentration: 7100 nM
Estimate against measurement, compound 3: 1.1-fold (0.05 log units) above; the measured number falls inside the stated range.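

In this assay, among these compounds, the first exchange that can be read at this position gives a 1.0-fold higher number from compound 1 to compound 3 (0.01 log units; within the scatter), so 2,4-dichlorophenyl and 4-nitrophenyl on the carbon with a double bond to nitrogen cannot be told apart here. The two groups are not alike in what they carry: one has two chlorine atoms and no hydrogen-bond acceptors, the other a nitro group with two hydrogen-bond acceptors, yet this difference leaves no mark beyond the scatter. No measurement on hand bears on why the two groups read alike.

From the compounds shown here alone, both groups are substituted phenyl rings, so it remains open whether this position can respond to a larger structural change. An amine or a carboxylic acid on that ring, or a longer carbon chain in place of the ring, would put that question to the test.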